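This account rests on a few compounds, and the source may have more. Where it says the series, first, only, none or still open, it means among the compounds named here.

Working notes on the thiazole amide series in an ADME assay on HepG2 2.2.15 cells (Homo sapiens) for cytotoxicity; on this read-out higher numbers stand for lower toxicity in this test and lower numbers for higher toxicity in this test.

Compound 1, `O=C(Nc1ncc(Cc2ccc(Br)cc2)s1)c1ccc2ccccc2c1`, carries the smallest set and in this assay its value reaches only a limit: compound 1 gives > 50000 nM, which is a limit of the assay and not a number. Compound 2, `O=C(Nc1ncc(C(Oc2ccc3cc(Br)ccc3c2)c2ccc(Cl)cc2)s1)c1cccs1`, gives "not toxic" (no number reported) in this assay. Compound 3, `O=C(Nc1ncc(C(OCc2ccc(Br)cc2)c2ccccc2)s1)c1cccs1`, gives "not toxic" (no number reported) in this assay. So compound 2 stands without a single number; of the two other entries, one is a limit and one has no number either, and the only quantitative anchor in the series is the limit of > 50000 nM in this assay, at which 1 of the 3 values shown sits.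

Compound 4, `CCOC(=O)CCCNc1ncc(C(Oc2ccc3cc(Br)ccc3c2)c2ccc(Cl)cc2)s1`, is not yet measured. It differs from compound 2 by 3-(ethoxycarbonyl)propyl in place of (thiophen-2-yl)carbonyl on a nitrogen on an aromatic ring. Among the measured compounds shown here, no measured step in this assay exists between compounds, so no size can be read from the data; the expectation is a step of no size beyond the scatter, in no direction, and most likely another limit.

In this assay compound 4 is expected at about 50000 nM, with the range 20000 nM to 100000 nM.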

Compound 4, half-maximal cytotoxic concentration: "not toxic" (no number reported)
The entry for compound 4 holds no number; the estimate stays without a comparison.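

Compound 2 and compound 4 both stand in this assay as "not toxic" with no number, so no step can be read between them. The compounds shown leave open whether exchanging the group on that nitrogen changes cytotoxicity at all, with only one quantitative anchor: the limit of > 50000 nM in this assay, at which 1 of the 4 values shown sits.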